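Acetyl on the hydroxymethyl of compound 2

This account rests on a few compounds, and the source may have more. Where it says the series, first, only, none or still open, it means among the compounds named here.

In a functional assay on SK-BR-3 cells (Homo sapiens) for cytotoxicity, read by MTT assay, with a stated time of 72 h (a higher number here means that more compound is needed for the effect, a lower number that less compound is needed), compound 1 `CCCOC(=O)c1c(C)coc1-c1ccc2c(CC)cccc2c1OC` gives > 10 ug/mL as a limit of the assay and not as a number. Among the measured compounds shown here, compound 2 `CCc1cccc2c(OC)c(-c3occ(C)c3CO)ccc12` gives 0.73 ug/mL there, the only true number so far. Compound 3 `CCc1cccc2c(OC)c(-c3occ(C)c3COC(C)=O)ccc12` differs from compound 2 by acetyl in place of hydrogen on an oxygen on a saturated carbon with acetyl in place of hydrogen on an oxygen on a saturated carbon, so hydroxymethyl becomes acetoxymethyl. For the measured compounds named here, the one measured step bearing on this is an at least 13-fold lower number from compound 1 to compound 2 (1.13 log units; beyond the scatter) for hydroxymethyl in place of propoxycarbonyl. Acetoxymethyl only loosely resembles propoxycarbonyl, so only a small part of that large step is expected to return, as a slightly higher number in this assay for compound 3. Compound 3 is estimated at 1.4 ug/mL with an expected range from 0.4 ug/mL to 6 ug/mL in this read-out. This expected a 1.9-fold higher number from compound 2 to compound 3 (0.28 log units; within the scatter) would stay close to the scatter.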

Compound 3, concentration for half-maximal effect: > 10 ug/mL
Compound 3 was reported as a limit; the forecaster's own chance of this, stated with the estimate: 15%; middle value at least 7.1-fold (0.85 log units) from the limit.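

Acetyl in place of hydrogen on this oxygen gives an at least 13-fold higher number from compound 2 to compound 3 (1.13 log units; beyond the scatter) in this assay. Thus the loss of propoxycarbonyl alone does not bring a measurable value: among these compounds, only compound 2, with its free hydroxymethyl, has one. The step between the other two compounds cannot be read, as both values are limits: the limit of > 10 ug/mL in this assay, at which 2 of the 3 values shown sit.

The compounds shown leave open whether the free hydroxy itself matters here, or whether an aminomethyl, a methoxymethyl or a carboxylic acid on the same aromatic carbon would also give a measurable value.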